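Shortening a fluorinated side chain on a weak activator

The source may report more compounds than this note shows. Statements on the series, on what has been measured and on what is new or still open speak of the compounds shown alone.

Compound 1 `CC1(C)C(=O)Nc2nc(-n3nc(CCCC(F)(F)F)c4cc(Cl)ccc43)nc(N)c21` holds the higher of the two numbers in an assay on CHO cells for activation of soluble guanylate cyclase alpha1/beta1 complex (Homo sapiens), read by cGMP accumulation (on this read-out lower numbers stand for an effect already at smaller amounts and higher numbers for an effect only at larger amounts of compound), giving 117000 nM. Among the measured compounds shown here, compound 2 `COC(=O)N(C)c1c(N)nc(-n2nc(Cc3ccccc3F)c3ccccc32)nc1N` gives 310 nM in this assay; the two values simply show a wide gap, with no single-point step linking them. Compound 3 `CC1(C)C(=O)Nc2nc(-n3nc(CCC(F)(F)F)c4cc(Cl)ccc43)nc(N)c21` differs from compound 1 only by trifluoromethyl in place of 2,2,2-trifluoroethyl on a saturated chain carbon, two bonds along the chain from an aromatic carbon. For the measured compounds named here, no measured pair shows this change, so there is no direct guide to its effect. The expected step of a 1.2-fold lower number from compound 1 to compound 3 (0.07 log units; within the scatter) is small, within the scatter, in no clear direction. Compound 3 is estimated at 100000 nM, between 30000 nM and 300000 nM.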

Compound 3, half-maximal effective concentration: 87000 nM
Beside the measured number, compound 3's estimate is 1.1-fold (0.06 log units) above it, and the stated range covers the measured number.
By their numbers in this assay, from the lowest: compound 2; then compounds 3 and 1 (each within the scatter of the next).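

At this saturated chain carbon, trifluoromethyl in place of 2,2,2-trifluoroethyl gives a 1.3-fold lower number from compound 1 to compound 3 (0.13 log units; within the scatter) in this assay as the first one-place step available here. Shortening the fluorinated chain therefore makes no change that can be told from the usual scatter, and the two compounds read alike. Nothing at hand offers an explanation for this result. What the compounds shown leave open is whether a different group at this place, such as an amine, a carboxylic acid or a plain propyl chain without fluorine, would move the number on this core.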